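Working notes: three measured analogues and one expected

The compounds below may be only part of what the source reports. "The series", "measured", "known", "first", "only" and "open" are said of these compounds alone.

Measured so far in a functional assay on HeLa cells (Homo sapiens) for cytotoxicity, read by sulforhodamine B assay, with a stated time of 48 h; a lower number here means a stronger inhibitor, a higher number a weaker inhibitor:

compound 1, `CC(=O)OC[C@H]1O[C@@H](n2cc(Cn3cc(C(C)=O)c4ccccc43)nn2)[C@H](OC(C)=O)[C@@H](OC(C)=O)[C@@H]1OC(C)=O`, gives > 200000 nM, a limit of the assay rather than a number.
compound 2, `COc1ccc(/C=C2\C(=O)N(Cc3cn([C@@H]4O[C@H](COC(C)=O)[C@@H](OC(C)=O)[C@H](OC(C)=O)[C@H]4OC(C)=O)nn3)c3ccccc32)cc1OC`, gives 63400 nM.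
compound 3, `CC(=O)OC[C@H]1O[C@@H](n2cc(CN3C(=O)/C(=C/c4ccc5ccccc5c4)c4ccccc43)nn2)[C@H](OC(C)=O)[C@@H](OC(C)=O)[C@@H]1OC(C)=O`, gives > 100000 nM, again a limit and not a number.

Among the compounds with values here, compound 2 is thus the only compound with a numeric reading in this assay; the other two values stand at limits, one at the limit of > 100000 nM in this assay, at which 1 of the 3 values shown sits, and one at the limit of > 200000 nM in this assay, at which 1 of the 3 values shown sits. Nothing is measured for compound 2 against any single-change partner, so no step size is known here.

Compound 4, `CC(=O)OC[C@H]1O[C@@H](n2cc(CN3C(=O)/C(=C\c4ccco4)c4ccccc43)nn2)[C@H](OC(C)=O)[C@@H](OC(C)=O)[C@@H]1OC(C)=O`, awaits measurement in this assay. Relative to compound 2 the change is furan-2-yl in place of 3,4-dimethoxyphenyl on a double-bonded chain carbon bound to a double-bonded ring carbon. Compound 3, which carries a different group at the same place, reached only a limit, so the series gives no sign that swapping this group gains potency. The expectation is a step of a 1.7-fold higher number from compound 2 to compound 4 (0.24 log units; within the scatter) from compound 2 to compound 4, weakening or at best no change beyond the scatter. Compound 4 is expected at 110000 nM, within 40000 nM to 300000 nM, with a fair chance that the assay reports only a limit.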

Compound 4, half-maximal inhibitory concentration: > 100000 nM
Compound 4: only a limit was reported; the forecaster's own chance of this, stated with the estimate: 50%; the middle value does not contradict the limit.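

In this assay compound 4 gives > 100000 nM, which is a limit of the assay and not a number: the limit of > 100000 nM in this assay, at which 2 of the 4 values shown sit.

Furan-2-yl in place of 3,4-dimethoxyphenyl on a double-bonded chain carbon bound to a double-bonded ring carbon gives an at least 1.5-fold higher number from compound 2 to compound 4 (0.19 log units; that floor lies within the scatter), so this change brings no measured gain in potency, but its true size stays unknown. Within the data shown here, compound 2 remains the only compound with a numeric reading, and this single-change pair now shows that a five-membered aromatic ring with one hetero atom at this place does not produce one.

Going by these compounds, how far the number for compound 4 lies from that of compound 2 stays open, since the printed floor of the step does not separate the pair from the usual scatter. Also open, on these data alone, is whether a phenyl ring carrying an amine or a carboxylic acid at this place, or free hydroxyl groups on the sugar in place of the acetyl esters, would give a numeric reading in this assay.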